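The source may hold more compounds than are shown below. What is called first, only, known or untested is meant among the compounds shown, and "the series" means these compounds.

Compound 1 `CCN1CCN(C[C@H]2CN(c3ccc(-n4cc(-c5ccccn5)cn4)c(F)c3)C(=O)O2)CC1`: 99 ug/mL
Compound 2 `O=C1O[C@@H](CN2CCC(c3ccc(F)cc3)CC2)CN1c1ccc(-n2cc(-c3ccccn3)cn2)c(F)c1`: > 400 ug/mL

Among the measured compounds shown here, in an ADME assay on HEK293-A cells (Homo sapiens) for cytotoxicity, read by MTT assay, with a stated time of 48 h (a higher number here means a weaker inhibitor, a lower number a stronger inhibitor), compound 1 gives 99 ug/mL, the only exact number so far. Compound 2 gives > 400 ug/mL, which is a limit of the assay rather than a number.

Compound 3 `O=C1CNC(=O)N1C[C@H]1CN(c2ccc(-n3cc(-c4ccccn4)cn3)c(F)c2)C(=O)O1` changes compound 1 at one place: 2,5-dioxoimidazolidin-1-yl in place of 4-ethylpiperazin-1-yl on a saturated chain carbon bound to a saturated ring carbon. For the measured compounds named here, no measured pair shows this change, so the expectation is uncertain. With compound 1 at 99 ug/mL as the sole exact anchor, a moderate move toward a higher number is expected, a 1.8-fold higher number from compound 1 to compound 3 (0.26 log units; within the scatter). For compound 3 the estimated value is 180 ug/mL, with an expected range of 60 ug/mL to 450 ug/mL.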

Compound 3, half-maximal inhibitory concentration: > 400 ug/mL
Compound 3 gave a limit, no number; the forecaster's own chance of this, stated with the estimate: 30%; middle value at least 2.2-fold (0.34 log units) from the limit.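

Putting 2,5-dioxoimidazolidin-1-yl in place of 4-ethylpiperazin-1-yl on this saturated chain carbon gives, in this assay, an at least 4.0-fold higher number from compound 1 to compound 3 (0.60 log units; beyond the scatter). So a single change of group at this place moves the read-out beyond the scatter, which the earlier compounds could not show. The full size of the step stays unknown, since compound 3 gives a limit of the assay and not a number: the limit of > 400 ug/mL in this assay, at which 2 of the 3 values shown sit.

Still open, as far as these compounds go, is where a morpholine ring or an open-chain dimethylamino group at this place would fall. Also open, from the compounds shown here alone, is how far the number can rise at this place.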